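Swapping a dichlorophenyl for a bromophenyl on the shared core

This account rests on a few compounds, and the source may have more. Where it says the series, first, only, none or still open, it means among the compounds named here.

Measured compounds:
compound 1 `Cc1ccc(C2=Nn3c(nnc3C(C)c3ccc(CC(C)C)cc3)SC2)cc1` gives 7300 nM
compound 2 `CC(c1ccc(-c2ccccc2)c(F)c1)c1nnc2n1N=C(c1ccc(Cl)cc1Cl)CS2` gives 8600 nM

In a functional assay on HepG2 cells (Homo sapiens) for inhibition, read by sulforhodamine B assay, with a stated time of 72 h (a lower number here means a stronger inhibitor, a higher number a weaker inhibitor), compound 2 gives 8600 nM. Within the data shown here, its only comparison is compound 1, which in this assay gives 7300 nM; the two numbers lie within the scatter of each other, so nothing separates them. Among the measured compounds shown here, compounds 1 and 2 also differ in several places at once, so no single step between measured compounds can be drawn from them.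

Compound 3 `CC(c1ccc(-c2ccccc2)c(F)c1)c1nnc2n1N=C(c1ccc(Br)cc1)CS2` has not yet been measured in this assay. It keeps the core of compound 2 and changes one group: 4-bromophenyl in place of 2,4-dichlorophenyl on a carbon with a double bond to nitrogen. For the measured compounds named here, the data hold no measured step for any change at this place, so the expectation rests on compound 2 alone.

Compound 3 is expected to stay close to compound 2, with a step of a 1.2-fold higher number from compound 2 to compound 3 (0.07 log units; within the scatter) that is unlikely to go beyond the scatter. The estimate for compound 3 in this assay is 10000 nM, with a range from 4000 nM to 25000 nM.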

Compound 3, half-maximal inhibitory concentration: 3700 nM
Estimate against measurement, compound 3: 2.7-fold (0.43 log units) above, outside the stated range (below it).
By their numbers in this assay, from the lowest: compounds 3, 1 and 2 (each within the scatter of the next, the first and the last beyond it).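

In this assay, among these compounds, the group on a carbon with a double bond to nitrogen turns out to matter: 4-bromophenyl in place of 2,4-dichlorophenyl brings a 2.3-fold lower number from compound 2 to compound 3 (0.37 log units; beyond the scatter) and gives the first step that can be tied to a single place on the shared core. The earlier pair could not show this, as its two compounds differ in several places at once and their numbers lie within the scatter of each other, whereas here everything outside this one group stays the same. Nothing in the data shown accounts for the step.

On these data alone, what remains open is how the two parts of this swap share the step, as the bromine enters and both chlorines leave together, so a 4-chlorophenyl at this place would be needed to begin separating them. As far as these compounds go, it is equally open how far this place tolerates other kinds of group, such as a 4-methoxyphenyl, an amine or a carboxylic acid on the phenyl ring, and whether the step would hold on a core carrying a different group on its other side.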